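This account rests on a few compounds, and the source may have more. Where it says the series, first, only, none or still open, it means among the compounds named here.

In a functional assay on HOS cells (Homo sapiens) for antiproliferative activity, with a stated time of 72 h (on this read-out lower numbers stand for stronger inhibition and higher numbers for weaker inhibition), three compounds on a shared core have been measured so far. Within the data shown here, compound 1 `OC[C@H]1O[C@@H](n2cnc3c(NCc4ccc(F)cc4)ncnc32)[C@H](O)[C@@H]1O` gives 13200 nM, the only actual number among them. Compound 2 `OC[C@H]1O[C@@H](n2cnc3c(NCc4ccc(Cl)cc4)ncnc32)[C@H](O)[C@@H]1O` reports only a limit, > 166000 nM. Compound 3 `Cc1cccc(CNc2ncnc3c2ncn3[C@@H]2O[C@H](CO)[C@@H](O)[C@H]2O)c1` likewise reports only a limit, > 166000 nM. Compound 3 therefore has no number of its own and stands at the limit of > 166000 nM in this assay, at which 2 of the 3 values shown sit.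

The next compound, compound 4 `OC[C@H]1O[C@@H](n2cnc3c(NCc4ccc(Cl)cc4Cl)ncnc32)[C@H](O)[C@@H]1O`, carries 2,4-dichlorophenyl in place of the 3-methylphenyl of compound 3, on a saturated chain carbon bound to a nitrogen on an aromatic ring: 2,4-dichlorophenyl in place of 3-methylphenyl on a saturated chain carbon bound to a nitrogen on an aromatic ring.

Among the measured compounds shown here, two measured steps bear on this change. Chloro in place of fluoro gave an at least 12-fold higher number from compound 1 to compound 2 (1.09 log units; beyond the scatter). Replacing 4-fluorophenyl with 3-methylphenyl gave an at least 12-fold higher number from compound 1 to compound 3 (1.09 log units; beyond the scatter). Both are large, and both end at a limit, so neither gives a number to build on. Between those two limits there is a step that the two limits leave unreadable from compound 2 to compound 3.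

Compound 4 has chlorine on its ring, as compound 2 does, so it is expected to stay close to the limit in this assay, with no clear gain over compound 3. The expected change is an at least 1.6-fold lower number from compound 3 to compound 4 (0.22 log units; that floor lies within the scatter). For compound 4 the estimated value is 100000 nM, within an expected range of 20000 nM to 166000 nM.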

Compound 4, half-maximal inhibitory concentration: > 166000 nM
Compound 4: only a limit was reported; the forecaster's own chance of this, stated with the estimate: 65%; at least 1.6-fold (0.22 log units) between middle value and limit.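

In this assay, compound 4 reports only a limit, so a second chlorine on the ring, and the 2,4-dichlorophenyl group as a whole, gives no measurable number on the shared core: the limit of > 166000 nM in this assay, at which 3 of the 4 values shown sit. The one step that can be read is an at least 12-fold higher number from compound 1 to compound 4 (1.09 log units; beyond the scatter), which shows that this position tolerates the 4-fluorophenyl of compound 1 but that none of the three other groups shown returns a number, whether it carries one chloro, two chloro groups or a methyl. Among these compounds, compound 1 is therefore the only compound of the four with a value, while the steps among compound 2, compound 3 and compound 4 cannot be read, since each of them ends in a limit on both sides.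

From the compounds shown here alone, it remains open whether the number of compound 1 depends on fluoro itself or whether a plain phenyl, a 4-methoxyphenyl or a 4-hydroxyphenyl at this position would also give a value. The compounds shown also leave unsettled how far apart compound 2, compound 3 and compound 4 actually lie.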